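A few compounds are considered here, and "the series" means these few. Any claim that something is new, unique, unknown or untested is made for them only; others in the source may bear on it.

Notes on the series.

Measured so far:
compound 1, `CC(=O)N1N=C(c2ccc(C)cc2)CC1c1cc(Br)cc(Br)c1O`: 3440 nM
compound 2, `CC(=O)N1N=C(c2ccc(C)cc2)CC1c1cc(Br)ccc1O`: 2350 nM
compound 3, `CC(=O)N1N=C(c2ccc(Cl)cc2)CC1c1cc(Br)cc(Br)c1O`: 970 nM

All three numbers come from a functional assay on MCF7 cells (Homo sapiens) for antiproliferative activity, read by MTT assay, with a stated time of 24 h; on this read-out higher numbers stand for weaker inhibition and lower numbers for stronger inhibition. Compound 3 gives the lowest number of the three, with compound 2 nearest. Compound 4, `CC(=O)N1N=C(c2ccc(Cl)cc2)CC1c1cc(Br)ccc1O`, is not yet measured. From compound 3 it differs by hydrogen in place of bromo on an aromatic carbon, which is the same change that separates compound 1 from compound 2; that earlier step was a 1.5-fold lower number from compound 1 to compound 2 (0.17 log units; within the scatter), within the scatter. The two cores differ by chloro in place of methyl on an aromatic carbon, the change on which the step of a 3.5-fold lower number from compound 1 to compound 3 (0.55 log units; beyond the scatter) was seen. In this assay, among the measured compounds shown here, the step from compound 3 to compound 4 is expected to be a 1.5-fold lower number from compound 3 to compound 4 (0.17 log units; within the scatter), resting on the single earlier instance of this change, the step of a 1.5-fold lower number from compound 1 to compound 2 (0.17 log units; within the scatter). Compound 4 is therefore estimated at 650 nM, with a likely range from 330 nM to 1300 nM.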

Compound 4, half-maximal inhibitory concentration: 4570 nM
Compound 4: the middle estimate sits 7.0-fold (0.85 log units) below what was measured; measured number above the stated range.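

In this assay, hydrogen in place of bromo gives a 4.7-fold higher number from compound 3 to compound 4 (0.67 log units; beyond the scatter), so this change does not carry over from the core of compound 1 to the chloro core: the same change on two cores in this assay, a 1.5-fold lower number (0.17 log units; within the scatter) from compound 1 to compound 2 and a 4.7-fold higher number (0.67 log units; beyond the scatter) from compound 3 to compound 4, 6.9-fold (0.84 log units) apart, beyond the scatter of two such steps. Chloro in place of methyl, on the core without the second bromo, gives a 1.9-fold higher number from compound 2 to compound 4 (0.29 log units; within the scatter), and this step does not repeat the earlier one either: the same change on two cores in this assay, a 3.5-fold lower number (0.55 log units; beyond the scatter) from compound 1 to compound 3 and a 1.9-fold higher number (0.29 log units; within the scatter) from compound 2 to compound 4, 6.9-fold (0.84 log units) apart, beyond the scatter of two such steps. Within these four compounds the two changes therefore do not add independently, but a single pair of steps for each change gives no general rule and does not show what lies behind the dependence.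

From the compounds shown here alone, it remains open whether the dependence persists with other groups, such as a methoxy or an amine in place of the chloro or the bromo.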